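Methoxy in Place of Vinyl at the Edge of Detection

The source may report more compounds than this note shows. Statements on the series, on what has been measured and on what is new or still open speak of the compounds shown alone.

Of the compounds shown here, two have been tested in an assay on cells for inhibition of HSP60/HSP10 (Homo sapiens), with a stated time of 60 min; a lower number here means a stronger inhibitor, a higher number a weaker inhibitor. Compound 1 `CS(=O)(=O)Nc1ccc(-c2nc3cc(NS(=O)(=O)c4ccc(Cl)s4)ccc3o2)cc1` gives 43000 nM, a weak result. Compound 2 `C=Cc1ccc(S(=O)(=O)Nc2ccc3oc(-c4ccccc4)nc3c2)cc1` reaches only the limit of this assay, > 100000 nM, so its true number is not known. For the measured compounds named here, this is the limit of > 100000 nM in this assay, at which 1 of the 2 values shown sits, and it says only that compound 2 is weaker than the assay can resolve. Compound 3 `COc1ccc(S(=O)(=O)Nc2ccc3oc(-c4ccccc4)nc3c2)cc1` has not yet been measured. It differs from compound 2 by methoxy in place of vinyl on an aromatic carbon. Going by the values given here, no measured pair shows how this change acts, so the size of the step can only be estimated. The expected step is a number no higher from compound 2 to compound 3 (the limit leaves the size open), which amounts to no change beyond the scatter. Compound 3 is therefore expected to give 100000 nM in this assay, within a range from 30000 nM to 300000 nM, and the assay may well report only a limit again.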

Compound 3, half-maximal inhibitory concentration: > 100000 nM
Compound 3: only a limit was reported; the forecaster's own chance of this, stated with the estimate: 70%; the middle value lies on the limit itself.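

For the compounds shown here, compound 2 and compound 3 both reach only a limit in this assay, so no step between them can be read: the limit of > 100000 nM in this assay, at which 2 of the 3 values shown sit. Still open, as far as these compounds go, are how weak compound 2 and compound 3 truly are, and whether vinyl or methoxy gives the stronger inhibitor.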